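This account rests on a few compounds, and the source may have more. Where it says the series, first, only, none or still open, it means among the compounds named here.

Three compounds have so far been measured in an ADME assay on microsomes (Homo sapiens) for metabolic stability; on this read-out lower numbers stand for a shorter-lived compound and higher numbers for a longer-lived compound:

Compound 1, `O=C(c1cscn1)N1CCC(C(=O)N2N=CC[C@H]2c2ccccc2)CC1`, gives > 3 h.
Compound 2, `N#Cc1cc(N2CCC(C(=O)N3N=CC[C@H]3c3cc(F)cc(F)c3)CC2)ncn1`, gives 3.3 h.
Compound 3, `CCC(=O)N1CCC(C(=O)N2N=CCC2c2ccccc2)CC1`, gives > 2.75 h.

The value of compound 1 is a limit of this assay, not a number (the limit of > 3 h in this assay, at which 1 of the 3 values shown sits). The value of compound 3 is likewise a limit of this assay (the limit of > 2.75 h in this assay, at which 1 of the 3 values shown sits). Compound 2 is therefore the only one of the three with an outright number; the other two values are limits, and its half-life sits close to where those limits lie, so no ordering among the three can be read from these figures.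

Compound 4, `N#Cc1nccc(N2CCC(C(=O)N3N=CC[C@H]3c3cc(F)cc(F)c3)CC2)n1`, has not yet been measured in this assay . It differs from compound 2 in one place: a group of 8 heavy atoms (5 carbon, 3 nitrogen; one six-membered aromatic ring with 2 hetero atoms) in place of a group of 8 heavy atoms (5 carbon, 3 nitrogen; one six-membered aromatic ring with 2 hetero atoms), on an amine nitrogen in a ring. The two compounds are built from the same atoms, joined differently; the group that enters is 2-cyanopyrimidin-4-yl.

Going by the values given here, no step between two measured compounds shows what such a change does to the half-life. The expectation is that the step from compound 2 to compound 4 stays within the usual scatter of this assay , in neither direction. Compound 4 is accordingly expected to give 3.3 h, most likely between 1.6 h and 6.5 h. The step this estimate implies is no change at the digits printed from compound 2 to compound 4 (within the scatter), and it is expected to be no larger than the scatter.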

Compound 4, half-life: 2.1 h
The estimate for compound 4 lay 1.6-fold (0.20 log units) above the measured number, within the range that was stated.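

Among the compounds shown, this is the only step between two compounds that differ in one place, and both of its ends are outright numbers rather than limits. In this assay, the same atoms rejoined as 2-cyanopyrimidin-4-yl on the amine nitrogen in the ring give a 1.6-fold lower number from compound 2 to compound 4 (0.20 log units; within the scatter), so the half-lives of these two compounds cannot be told apart, and this rearrangement of the group has no effect that can be read beyond the scatter. Nothing measured here gives a reason for this result.

Going by these compounds, it remains open whether that holds only for these two arrangements or also for larger changes at the same place. An amine or a carboxylic acid in place of the nitrile, for example, could behave quite differently in this ring system.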